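The source may report more compounds than this note shows. Statements on the series, on what has been measured and on what is new or still open speak of the compounds shown alone.

Measured compounds in a functional assay on HT-1080 cells (Homo sapiens) for cytotoxicity, read by MTT assay, with a stated time of 72 h; on this read-out lower numbers stand for stronger inhibition and higher numbers for weaker inhibition:
Compound 1 `COc1ccc(Cn2cc3cc(C(=N)Nc4ccc(N5CCN(C)CC5)cc4)ncc3n2)cc1` gives 3200 nM.
Compound 2 `Cn1nc(-c2ccccc2)c2cc(C(=N)Nc3ccccc3)ncc21` gives 17400 nM.
Compound 3 `CN1CCN(c2ccc(NC(=N)c3cc4cn(C)nc4cn3)cc2)CC1` gives 21000 nM.

Compound 3 and compound 1 differ in one place, (4-methoxyphenyl in place of hydrogen on a saturated chain carbon bound to an aromatic nitrogen), and in this assay this change made a step of a 6.6-fold lower number from compound 3 to compound 1 (0.82 log units; beyond the scatter). Compound 2 shares that same saturated chain carbon bound to an aromatic nitrogen bearing only a methyl, but its core differs from that of compound 3 in a way that is not broken down here; its values stand near compound 3 and well apart from compound 1.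

Compound 4 `COc1ccc(Cn2nc(-c3ccccc3)c3cc(C(=N)Nc4ccccc4)ncc32)cc1` is the not yet measured partner of compound 2, carrying the same kind of change, (4-methoxyphenyl in place of hydrogen on a saturated chain carbon bound to an aromatic nitrogen). For the measured compounds named here, because the one measured example, a 6.6-fold lower number from compound 3 to compound 1 (0.82 log units; beyond the scatter), was beyond the usual scatter, the same change is expected to lower the number for compound 4 as well, though with only a single precedent on a different core the size is uncertain. The expected step from compound 2 to compound 4 in this assay is a 4.0-fold lower number from compound 2 to compound 4 (0.60 log units; beyond the scatter). For compound 4 the estimate in this assay is 4400 nM, with a likely range from 1500 nM to 13000 nM.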

Compound 4, half-maximal inhibitory concentration: 4700 nM
Beside the measured number, compound 4's estimate is 1.1-fold (0.03 log units) below it, within the range that was stated.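

In this assay, the change from methyl to 4-methoxybenzyl on the aromatic nitrogen lowered the number on a second core, with a 3.7-fold lower number from compound 2 to compound 4 (0.57 log units; beyond the scatter). Set beside the earlier step, the new one points the same way, and the two sizes do not differ beyond the scatter: the same change on two cores in this assay, a 6.6-fold lower number (0.82 log units; beyond the scatter) from compound 3 to compound 1 and a 3.7-fold lower number (0.57 log units; beyond the scatter) from compound 2 to compound 4, 1.8-fold (0.25 log units) apart, within the scatter of two such steps

This shows that the change carried over between these two cores, in both direction and comparable size, but two pairs say nothing about any further core and do not explain why the number falls.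

The compounds shown carry only methyl or 4-methoxybenzyl at this place, and it remains open whether a plain benzyl, a longer chain or a chain ending in an amine would give a similar step. For the compounds shown here, also open is whether the step depends on the other parts in which the two pairs differ, as no pair here separates those parts from the change.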